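This account rests on a few compounds, and the source may have more. Where it says the series, first, only, none or still open, it means among the compounds named here.

Compound 1 `O=C1CSC(N2N=C(c3ccc(Cl)cc3)CC2c2cccc3ccccc23)=N1` carries a chloro-substituted phenyl ring on the shared core, and in a functional assay on HepG2 cells (Homo sapiens) for inhibition, read by CCK-8 assay, with a stated time of 48 h (on this read-out higher numbers stand for weaker inhibition and lower numbers for stronger inhibition), compound 1 gives 16500 nM. Two companions have been measured alongside it. Compound 2 `Brc1ccc(C2=NN(C3=NC(c4ccccc4)CS3)C(c3ccc4ccccc4c3)C2)cc1` gives 20300 nM, and compound 3 `Clc1ccc(C2=NN(C3=NC(c4ccccc4)CS3)C(c3cccc4ccccc34)C2)cc1` gives 18700 nM. Against compound 3 the step is a 1.1-fold higher number from compound 1 to compound 3 (0.05 log units; within the scatter), and the gap to compound 2 is likewise within the scatter, so the three numbers sit together and none of them can be called stronger or weaker than another; compound 1 simply stands in that cluster.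

The change to compound 4 `COc1ccc(C2=NN(C3=NC(=O)CS3)C(c3cccc4ccccc34)C2)cc1` is methoxy in place of chloro on an aromatic carbon. No measured pair among these three compounds swaps a chloro for a methoxy, so there is no step that speaks directly to this change. Going by the values given here, the one step that was measured, from compound 1 to compound 3, altered a different part of the molecule and stayed within the scatter, and the numbers across all three compounds barely move. On that basis the expectation for compound 4 is no shift beyond the scatter, and the step from compound 1 to compound 4 is estimated as a 1.0-fold higher number from compound 1 to compound 4 (0.01 log units; within the scatter). Compound 4 is therefore expected to give about 17000 nM in this assay, within a range from 7000 nM to 40000 nM.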

Compound 4, half-maximal inhibitory concentration: 7850 nM
Compound 4: the middle estimate sits 2.2-fold (0.34 log units) above what was measured, within the range that was stated.
By their numbers in this assay, from the lowest: compound 4; then compounds 1, 3 and 2 (each within the scatter of the next).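

In this assay, the position para to a large group turns out to respond to what sits on it: the change from 4-chlorophenyl to 4-methoxyphenyl gives a 2.1-fold lower number from compound 1 to compound 4 (0.32 log units; beyond the scatter), and on this read-out a lower number stands for stronger inhibition. Going by these compounds alone, the earlier compounds could not show this, since their numbers all lay within the scatter of one another, and the one step among them, a 1.1-fold higher number from compound 1 to compound 3 (0.05 log units; within the scatter), concerned a different part of the molecule. This is a modest step and a single pair, so it establishes a direction for one swap rather than a trend, and nothing measured here gives a reason for the shift.

From the compounds shown here alone, it remains open whether a hydroxy group, an amine or a longer chain such as ethoxy on the same aromatic carbon would take the number lower still or bring it back towards that of compound 1. Going by these compounds, it is also open whether the same swap from chloro to methoxy would lower the number by a similar amount on compound 3, where a larger group sits on the amine nitrogen in the ring.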